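The source may report more compounds than this note shows. Statements on the series, on what has been measured and on what is new or still open speak of the compounds shown alone.

Measured in a functional assay on M14 cells (Homo sapiens) for inhibition, read by sulforhodamine B assay, with a stated time of 48 h; on this read-out higher numbers stand for weaker inhibition of growth and lower numbers for stronger inhibition of growth:

compound 1 `COc1cc(C)cc(-c2c(-c3ccnc(-c4ccc(C(C)=O)cc4)c3)cnn2CC#N)c1`: 1970 nM
compound 2 `Cc1cc(O)cc(-c2nn(CC#N)cc2-c2ccnc(-c3ccc(Oc4ccccc4)cc3)c2)c1`: 1700 nM
compound 3 `Cc1cc(O)cc(-c2nn(CC#N)cc2-c2ccnc(-c3ccc(N(C)C)cc3)c2)c1`: 1830 nM

The three numbers lie close together. Compound 1 has the highest of the three, but its gap to compound 3 and to compound 2 is within the scatter, so no order among them can be read from this assay.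

Compound 4 `COc1cc(C)cc(-c2c(-c3ccnc(-c4ccc(N(C)C)cc4)c3)cnn2CC#N)c1` is not yet measured. Against compound 1 the change is dimethylamino in place of acetyl on an aromatic carbon. Among the measured compounds shown here, no measured pair carries exactly this exchange. For the measured compounds named here, the one step that touches the same position, a 1.1-fold higher number from compound 2 to compound 3 (0.03 log units; within the scatter), swaps a different group for dimethylamino and does nothing beyond the scatter. Compound 1 and compound 3 differ in two places at once and still sit within the scatter of each other, which gives no sign that the dimethylamino end moves this assay much.

The expectation for compound 4 is therefore a step of about a 1.1-fold lower number from compound 1 to compound 4 (0.04 log units; within the scatter), not beyond the scatter. Compound 4 is estimated at 1800 nM, with a range from 900 nM to 3600 nM.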

Compound 4, concentration for 50% growth inhibition: 54.1 nM
Compound 4: the middle estimate sits 33-fold (1.52 log units) above what was measured; measured number outside the range, below it.
By their numbers in this assay, from the lowest: compound 4; then compounds 2, 3 and 1 (each within the scatter of the next).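

In this assay the exchange of 4-acetylphenyl for 4-(dimethylamino)phenyl gives a 36-fold lower number from compound 1 to compound 4 (1.56 log units; beyond the scatter) and so shows that this place, on a six-membered aromatic ring of carbon only and para to a large group, can move the read-out strongly. The earlier step of a 1.1-fold higher number from compound 2 to compound 3 (0.03 log units; within the scatter) showed no such movement, so a flat result for one exchange at this place does not carry over to another. Leaving and entering groups match in heavy-atom, donor and acceptor counts and in net charge, so these counts do not separate them, and no measurement here gives a reason for the step.

On these data alone, whether a primary amine or morpholine at this place on the core of compound 4 keeps the low number remains open. So does the effect of a carboxylic acid there.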